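This account rests on a few compounds, and the source may have more. Where it says the series, first, only, none or still open, it means among the compounds named here.

The measured compounds and their values in a functional assay on SK-BR-3 cells (Homo sapiens) for cytotoxicity, read by MTT assay, with a stated time of 72 h; on this read-out lower numbers stand for stronger inhibition and higher numbers for weaker inhibition:

compound 1 `COc1cccc(CNC(=O)c2nc(Br)c3cccnc3c2N[C@H]2CC[C@H](N)CC2)c1`: 6000 nM
compound 2 `Nc1ccc(Nc2c(C(=O)NCc3ccc(F)cc3)nc(Br)c3cccnc23)cc1`: 4000 nM
compound 3 `N[C@H]1CC[C@H](Nc2c(C(=O)NCc3ccco3)nc(Br)c3cccnc23)CC1`: 10000 nM

Compound 3 carries the highest of the three numbers, but its distance to compound 1 is within the scatter, so only compound 2 sits clearly apart from it, with a lower number. Compound 4 `N[C@H]1CC[C@H](Nc2c(C(=O)NCc3ccc(Cl)cc3Cl)nc(Br)c3cccnc23)CC1` shares the core of compound 3 and differs from it in one place: 2,4-dichlorophenyl in place of furan-2-yl on a saturated chain carbon bound to an amide-type nitrogen. Among the compounds with values here, one measured step bears on this spot. From compound 1 to compound 3 the group on that same saturated chain carbon was exchanged, with a 1.7-fold higher number from compound 1 to compound 3 (0.22 log units; within the scatter). That single swap of one aromatic group for another left the number essentially unchanged. Within the data shown here, the new swap at the same spot, to the 2,4-dichlorophenyl group, has no measured counterpart of its own, so no direction beyond the scatter can be foreseen from the numbers at hand. The expectation for compound 4 is therefore a step about the size of the scatter, leaning if anything toward a lower number: a 2.0-fold lower number from compound 3 to compound 4 (0.30 log units; within the scatter). Compound 4 is thus estimated at 5000 nM in this assay, with a likely range from 2000 nM to 15000 nM.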

Compound 4, half-maximal inhibitory concentration: 6000 nM
Estimate against measurement, compound 4: 1.2-fold (0.08 log units) below, within the range that was stated.
By their numbers in this assay, from the lowest: compounds 2, 1, 4 and 3 (each within the scatter of the next, the first and the last beyond it).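

In this assay, the group on the saturated chain carbon bound to an amide-type nitrogen now has three aromatic versions, and the step of a 1.7-fold lower number from compound 3 to compound 4 (0.22 log units; within the scatter) stays within the scatter even though a five-membered aromatic ring with one oxygen gives way to a six-membered ring of carbon only that carries two chlorines. The step of no change at the digits printed from compound 1 to compound 4 (within the scatter) gives the same reading for 2,4-dichlorophenyl against 3-methoxyphenyl, and with it compound 1, compound 3 and compound 4 form a set in which no aromatic group stands clearly apart from the other two at this spot. No measurement at hand explains why the number responds so little to these exchanges.

All three groups are aromatic rings on that same saturated chain carbon, which leaves open whether a non-aromatic group such as cyclohexyl, or a phenyl ring carrying a carboxylic acid or an amine, would move the number beyond the scatter. Also open, as far as these compounds go, is whether a longer chain between the ring and the amide-type nitrogen would do so.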